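Cytotoxicity notes on the urea series: carboxy to acetyl

The source may hold more compounds than are shown below. What is called first, only, known or untested is meant among the compounds shown, and "the series" means these compounds.

Measured so far in an ADME assay on HEK293 cells (Homo sapiens) for cytotoxicity, with a stated time of 72 h; a higher number here means that more compound is needed for the effect, a lower number that less compound is needed:
compound 1 `Cc1cc(NC(=O)Nc2ccc(C(=O)O)cc2)c2ccccc2n1`: > 25000 nM
compound 2 `Cc1cc(NC(=O)Nc2cc(F)ccc2F)c2ccccc2n1`: 12000 nM
compound 3 `CSc1ccccc1NC(=O)Nc1cc(C)nc2ccccc12`: > 25000 nM

Compound 1 gives > 25000 nM, which is a limit of this assay, not a number. Compound 1 thus stands at the limit of > 25000 nM in this assay, at which 2 of the 3 values shown sit. Compound 3 also sits at a limit, > 25000 nM. Only compound 2 gives a number in this assay, 12000 nM. Among the compounds with values here, no pair of these three differs in one place, so no step between measured compounds can be read, and nothing here points to a cause for the one numeric value.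

Compound 4 `CC(=O)c1ccc(NC(=O)Nc2cc(C)nc3ccccc23)cc1` is the next compound. It differs from compound 1 by methyl in place of hydroxy on a carbonyl carbon. Within the data shown here, with two of three values at a limit and no measured step to lean on, the expected step from compound 1 to compound 4, an at least 1.2-fold lower number from compound 1 to compound 4 (0.09 log units; that floor lies within the scatter), is none beyond the scatter, and compound 4 is expected to sit near the limit again. The estimate for compound 4 in this assay is 20000 nM, with a range of 7000 nM to 50000 nM.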

Compound 4, half-maximal effective concentration: > 25000 nM
Compound 4: only a limit was reported; the forecaster's own chance of this, stated with the estimate: 55%; middle value at least 1.2-fold (0.09 log units) away from the limit.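

In this assay compound 4 gives > 25000 nM, which is a limit and not a number. Compound 1 is also at a limit, so no step between compound 1 and compound 4 can be read: the limit of > 25000 nM in this assay, at which 3 of the 4 values shown sit.

From the compounds shown here alone, whether carboxy to acetyl shifts the read-out in this assay at all stays open.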